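The source may report more compounds than this note shows. Statements on the series, on what has been measured and on what is new or still open speak of the compounds shown alone.

Working notes on the amide substituent of the shared core, read in a functional assay on K562 cells (Homo sapiens) for cytotoxicity, read by MTT assay, with a stated time of 48 h; on this read-out higher numbers stand for weaker inhibition and lower numbers for stronger inhibition. Compound 1 `CCNC(=O)CC[C@H](NS(=O)(=O)c1ccc([N+](=O)[O-])cc1)C(=O)O` gives only a limit, > 500000 nM, as noted in the limit of > 500000 nM in this assay, at which 1 of the 3 values shown sits. Compound 2 `CC(C)NC(=O)CC[C@H](NS(=O)(=O)c1ccc([N+](=O)[O-])cc1)C(=O)O` gives 19800 nM, and compound 3 `CCCCNC(=O)CC[C@H](NS(=O)(=O)c1ccc([N+](=O)[O-])cc1)C(=O)O` gives 19700 nM. Compound 3 thus shares the measured range with compound 2, the two lying within the scatter of each other, while the remaining entry is a limit.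

Compound 4 `CCCCCNC(=O)CC[C@H](NS(=O)(=O)c1ccc([N+](=O)[O-])cc1)C(=O)O` differs from compound 3 by methyl in place of hydrogen on a saturated chain carbon, four bonds along the chain from an amide-type nitrogen.

For the measured compounds named here, two measured steps bear on this change. The step of an at least 25-fold lower number from compound 1 to compound 3 (1.40 log units; beyond the scatter) is large but starts from a limit, and it shows that the butyl amide is clearly more active than the starting compound in this series. The step of a 1.0-fold lower number from compound 2 to compound 3 (0.00 log units; within the scatter) shows no separation between isopropyl and butyl on the amide nitrogen. With compound 3 at 19700 nM, a further single carbon at the chain end is therefore expected to bring little change. The expected step is a 1.3-fold lower number from compound 3 to compound 4 (0.12 log units; within the scatter), which would stay within the scatter. For compound 4 the estimated value is 15000 nM, with an expected range of 6000 nM to 40000 nM.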

Compound 4, half-maximal inhibitory concentration: 17900 nM
Beside the measured number, compound 4's estimate is 1.2-fold (0.08 log units) below it; the measured number falls inside the stated range.
By their numbers in this assay, from the lowest: compounds 4, 3 and 2 (each within the scatter of the next). At a limit, above all of these: compound 1.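

In this assay, methyl in place of hydrogen on a saturated chain carbon, four bonds along the chain from an amide-type nitrogen, gives a 1.1-fold lower number from compound 3 to compound 4 (0.04 log units; within the scatter), and pentyl in place of isopropyl on the amide-type nitrogen gives a 1.1-fold lower number from compound 2 to compound 4 (0.04 log units; within the scatter), so the isopropyl, butyl and pentyl amides of compounds 2, 3 and 4 now form a level stretch with no order among them. Compound 1, the ethyl amide, goes against this level stretch with an at least 27-fold lower number from compound 1 to compound 4 (1.44 log units; beyond the scatter), a step that starts from a limit and not from a number: the limit of > 500000 nM in this assay, at which 1 of the 4 values shown sits. The same added methyl therefore has no single size of effect in this series, and its size depends on the chain it extends: the same change on two cores in this assay, an at least 25-fold lower number (1.40 log units; beyond the scatter) from compound 1 to compound 2 and a 1.1-fold lower number (0.04 log units; within the scatter) from compound 3 to compound 4, at least 22-fold (1.36 log units) apart, beyond the scatter of two such steps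

The compounds shown leave open whether the level stretch continues to a longer chain such as hexyl or octyl, or holds for a cyclohexyl group or a chain ending in an amine or a carboxylic acid. They also leave open where the drop in activity sets in between the ethyl amide and the isopropyl amide, a point that a propyl amide would address.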